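The source may report more compounds than this note shows. Statements on the series, on what has been measured and on what is new or still open speak of the compounds shown alone.

In a functional assay on HT-29 cells (Homo sapiens) for antiproliferative activity, read by sulforhodamine B assay, with a stated time of 48 h (a higher number here means a weaker inhibitor, a lower number a stronger inhibitor), compound 1 `O=C1NCCN1c1ccc(S(=O)(=O)Nc2ccc(C3CCCCC3)cc2)cc1` gives > 1000 nM as a limit of the assay and not a number. Compound 3 `CC(C)(C)c1ccc(NS(=O)(=O)c2ccc(N3CCNC3=O)cc2)cc1` gives > 1000 nM as a limit too, so it has no number of its own. Among the compounds with values here, compound 2 `CCCCc1ccc(NS(=O)(=O)c2ccc(N3CCNC3=O)cc2)cc1` reads 610 nM as the only true number so far. Compound 4 `CC(C)Cc1ccc(NS(=O)(=O)c2ccc(N3CCNC3=O)cc2)cc1` has the same atoms as compound 3, joined differently: isobutyl in place of tert-butyl on an aromatic carbon with isobutyl in place of tert-butyl on an aromatic carbon. The closest measured change is an at least 1.6-fold higher number from compound 2 to compound 3 (0.21 log units; that floor lies within the scatter) and that floor lies within the scatter, as does the floor of an at least 1.6-fold lower number from compound 1 to compound 2 (0.21 log units; that floor lies within the scatter) in the other readable step. Isobutyl is nearer by name to the butyl of compound 2 at 610 nM than tert-butyl is, so a modest shift is expected in this assay towards a lower number. The estimated step is an at least 1.4-fold lower number from compound 3 to compound 4 (0.15 log units; that floor lies within the scatter) and it may not clear the scatter. For compound 4 the estimated value is 700 nM with 300 nM to 1600 nM as its expected range.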

Compound 4, half-maximal inhibitory concentration: > 1000 nM
Compound 4 was reported as a limit; the forecaster's own chance of this, stated with the estimate: 35%; middle value at least 1.4-fold (0.15 log units) away from the limit.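

In this assay compound 4, with isobutyl on the aromatic carbon, gives > 1000 nM, a limit of the assay and not a number. Within the data shown here, measured against the unbranched butyl, the only readable new change is an at least 1.6-fold higher number from compound 2 to compound 4 (0.21 log units; that floor lies within the scatter), so even this floor does not show that the branched chain differs from butyl. The steps from compound 1 and compound 3 to compound 4 cannot be read, and only compound 2 has a true number, the others sitting at one shared value: the limit of > 1000 nM in this assay, at which 3 of the 4 values shown sit.

Going by these compounds, how far compound 1, compound 3 and compound 4 lie past that limit stays open. So does whether a shorter chain such as propyl, or an amine or a carboxylic acid at this position, would give a true number.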